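The compounds below may be only part of what the source reports. "The series", "measured", "known", "first", "only" and "open" are said of these compounds alone.

Among the measured compounds shown here, in a functional assay on DU-145 cells (Homo sapiens) for cytotoxicity, read by sulforhodamine B assay, with a stated time of 48 h (on this read-out higher numbers stand for weaker inhibition of growth and lower numbers for stronger inhibition of growth), compound 2 `N#Cc1ccc(Nc2nc(Oc3ccnc4ccccc34)nc(N3CCN(c4ncccn4)CC3)n2)cc1C(F)(F)F` gives 85200 nM; the only other number in hand comes from compound 1 `N#Cc1ccc(Nc2nc(Oc3ccnc4ccccc34)nc(N3CCN(c4ccccc4Cl)CC3)n2)cc1C(F)(F)F`, which gives 92600 nM, and the two lie within the scatter of each other. Compound 3 `N#Cc1ccc(Nc2nc(Oc3ccnc4ccccc34)nc(N3CCN(c4ccccc4F)CC3)n2)cc1C(F)(F)F` carries 2-fluorophenyl in place of pyrimidin-2-yl on an amine nitrogen in a ring. For the measured compounds named here, the one step that bears on this, an aryl swap on the same ring nitrogen, is a 1.1-fold lower number from compound 1 to compound 2 (0.04 log units; within the scatter). On that basis no step beyond the scatter is expected in this assay: a 1.0-fold higher number from compound 2 to compound 3 (0.01 log units; within the scatter). Compound 3 is therefore estimated at 88000 nM, with a range from 40000 nM to 200000 nM.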

Compound 3, concentration for 50% growth inhibition: > 100000 nM
Compound 3 gave a limit, no number; the forecaster's own chance of this, stated with the estimate: 10%; at least 1.1-fold (0.05 log units) between middle value and limit.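

Compound 3 gives a limit of the assay, not a number, in this assay and joins the top of the measurable range: the limit of > 100000 nM in this assay, at which 1 of the 3 values shown sits. Read as floors, an at least 1.1-fold higher number from compound 2 to compound 3 (0.06 log units; that floor lies within the scatter) and an at least 1.0-fold higher number from compound 1 to compound 3 (0.03 log units; that floor lies within the scatter) both stay within the scatter, so 2-fluorophenyl on this amine nitrogen in a ring is not separated from pyrimidin-2-yl, nor fluoro from chloro. The full size of either step cannot be read.

Open, on these data alone, is whether an amine or a carboxylic acid on the phenyl ring, or a longer chain on this nitrogen in place of the aromatic ring, would give a lower number in this assay than those seen here.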